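Chloro to bromo on the fluorinated series

This account rests on a few compounds, and the source may have more. Where it says the series, first, only, none or still open, it means among the compounds named here.

Values in a functional assay on MCF7 cells (Homo sapiens) for inhibition; on this read-out lower numbers stand for stronger inhibition and higher numbers for weaker inhibition:
- compound 1 `COc1ccc(-c2nc3cc(F)ccc3s2)cc1`: 490 nM
- compound 2 `COc1ccc(-c2nc3cc(F)ccc3s2)cc1C`: 48 nM
- compound 3 `COc1ccc(-c2nc3cc(F)ccc3s2)cc1Cl`: 760 nM

Compound 3 shares the high end of the numbers with its hydrogen parent, from which it is not separated: a 1.6-fold higher number from compound 1 to compound 3 (0.19 log units; within the scatter). The methyl analogue lies far lower: a 16-fold higher number from compound 2 to compound 3 (1.20 log units; beyond the scatter).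

The next compound is compound 4 `COc1ccc(-c2nc3cc(F)ccc3s2)cc1Br`, not yet measured in this assay. The change is bromo in place of chloro on an aromatic carbon, ortho to a methoxy group.

Going by the values given here, the closest precedent is the introduction of chloro, a 1.6-fold higher number from compound 1 to compound 3 (0.19 log units; within the scatter), which stayed within the scatter. The large steps both involve methyl: a 10-fold lower number from compound 1 to compound 2 (1.01 log units; beyond the scatter) and a 16-fold higher number from compound 2 to compound 3 (1.20 log units; beyond the scatter). Among the compounds with values here, the series holds no bromo compound, so the data cannot show whether bromo tracks chloro or methyl. Tracking chloro is the more likely outcome, so no step beyond the scatter is expected, with the range left wider towards lower numbers. The expected change is a 1.5-fold lower number from compound 3 to compound 4 (0.18 log units; within the scatter). For compound 4 the estimated value is 500 nM, with an expected range of 150 nM to 1300 nM.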

Compound 4, half-maximal inhibitory concentration: 850 nM
The estimate for compound 4 lay 1.7-fold (0.23 log units) below the measured number; low and high end bracket the measured number.
By their numbers in this assay, from the lowest: compound 2; then compounds 1, 3 and 4 (each within the scatter of the next).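

Working notes on this position, ortho to a methoxy group: in this assay, bromo in place of chloro gives a 1.1-fold higher number from compound 3 to compound 4 (0.05 log units; within the scatter) and bromo in place of hydrogen gives a 1.7-fold higher number from compound 1 to compound 4 (0.24 log units; within the scatter), so at this place neither halogen separates from the other or from the hydrogen parent. The earlier compounds shown here offered a single halogen, while the series now holds two, and both sit apart from the methyl analogue, with an 18-fold higher number from compound 2 to compound 4 (1.25 log units; beyond the scatter) as a second large step of the same direction and similar size as a 16-fold higher number from compound 2 to compound 3 (1.20 log units; beyond the scatter). Among the four compounds, compound 2 is thus the only one that stands out, and compounds 1, 3 and 4 form one group; no measurement at hand bears on why this place separates methyl from the halogens.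

Open, from the compounds shown here alone, is whether ethyl, a longer chain, trifluoromethyl, a nitrile or an amine at this place would fall with compound 2 or with compounds 1, 3 and 4. Also open, going by these compounds, is whether the separation of methyl from hydrogen and the halogens would persist on the shared core with the fluoro group replaced by another substituent, such as methoxy.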